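Solubility notes on three measured analogues and one proposed

This account rests on a few compounds, and the source may have more. Where it says the series, first, only, none or still open, it means among the compounds named here.

Measured so far in a physicochemical assay for solubility, read by LC-MS, in phosphate buffer, with a stated time of 24 h, at pH 7.4; on this read-out higher numbers stand for higher solubility and lower numbers for lower solubility:
compound 1 `Cc1cc(-c2cnc(NCc3c(F)ccc4c3CCO4)c3cn[nH]c(=O)c23)n(C)n1` gives 1000 nM
compound 2 `Cn1nccc1-c1cnc(NCc2c(F)ccc3c2CCO3)c2cn[nH]c(=O)c12` gives 2000 nM
compound 3 `Cc1nc(CO)ccc1-c1cnc(NCc2c(F)ccc3c2CCO3)c2cn[nH]c(=O)c12` gives 3000 nM

Compound 3 has the highest number of the three in this assay. Its margin over compound 2 is a 1.5-fold higher number from compound 2 to compound 3 (0.18 log units; within the scatter), which does not separate the two; its margin over compound 1 is a 3.0-fold higher number from compound 1 to compound 3 (0.48 log units; beyond the scatter), a modest but real gap. For the measured compounds named here, the only other step among the measured compounds, a 2.0-fold higher number from compound 1 to compound 2 (0.30 log units; within the scatter), concerns the methyl on the pyrazole and changes little.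

The next compound, compound 4 `Cc1ncc(-c2cnc(NCc3c(F)ccc4c3CCO4)c3cn[nH]c(=O)c23)n1C`, differs from compound 3 in one place: 1,2-dimethyl-1H-imidazol-5-yl in place of 6-(hydroxymethyl)-2-methylpyridin-3-yl on an aromatic carbon. The group entering is a five-membered aromatic ring with two hetero atoms carrying two methyls and no hydrogen-bond donor, which makes it closer in kind to the group in compound 1 than to the pyridinyl of compound 3. Going by the values given here, the steps that bear on this position, a 3.0-fold higher number from compound 1 to compound 3 (0.48 log units; beyond the scatter) and a 1.5-fold higher number from compound 2 to compound 3 (0.18 log units; within the scatter), both ran toward compound 3; the return toward a dimethyl azole is therefore expected to undo part of that gain. A step of about a 2.3-fold lower number from compound 3 to compound 4 (0.36 log units; beyond the scatter) is expected in this assay. Compound 4 is estimated at 1300 nM, with a range from 600 nM to 3000 nM.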

Compound 4, solubility: 15000 nM
Estimate against measurement, compound 4: 12-fold (1.06 log units) below; the measured number lies above the stated range.
By their numbers in this assay, from the lowest: compounds 1, 2 and 3 (each within the scatter of the next, the first and the last beyond it); then compound 4.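

In this assay, the kind of five-membered ring at this position counts for more than the first three compounds could show: with two methyls on each ring, 1,2-dimethyl-1H-imidazol-5-yl in place of 1,3-dimethyl-1H-pyrazol-5-yl gives a 15-fold higher number from compound 1 to compound 4 (1.18 log units; beyond the scatter), the largest step in the set. The 6-(hydroxymethyl)-2-methylpyridin-3-yl group also no longer marks the top of the range, as a group with 0 hydrogen-bond donors gives a 5.0-fold higher number from compound 3 to compound 4 (0.70 log units; beyond the scatter), while the step against the 1-methyl-1H-pyrazol-5-yl group is a 7.5-fold higher number from compound 2 to compound 4 (0.88 log units; beyond the scatter). No measurement at hand offers an explanation for these steps.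

As far as these compounds go, whether the higher number goes with the imidazole ring itself or with the way its two methyls are placed remains open, and a comparison of 1-methyl-1H-imidazol-5-yl with 1,2-dimethyl-1H-imidazol-5-yl would separate the ring from the added methyl. Also open, from the compounds shown here alone, is how far the step carries over when the imidazole bears a further group, such as an aminomethyl chain or a carboxylic acid, in place of one of its methyls.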